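From acetoxy to a hydroxyl-ended chain

The source may report more compounds than this note shows. Statements on the series, on what has been measured and on what is new or still open speak of the compounds shown alone.

- Compound 1 `NS(=O)(=O)c1ccc(SCCO)c([N+](=O)[O-])c1` gives 500 ug/mL 
- Compound 2 `CC(=O)OCCS(=O)(=O)c1ccc(S(N)(=O)=O)s1` gives 880 ug/mL 

Both values come from a physicochemical assay for solubility, at pH 7.4 (on this read-out lower numbers stand for lower solubility and higher numbers for higher solubility), and lie within the usual scatter of each other, so compound 2 stands level with compound 1. Compound 3 `NS(=O)(=O)c1ccc(S(=O)(=O)CCCCO)s1` has not been measured yet. It differs from compound 2 by one change 2-hydroxyethyl in place of acetoxy on a saturated chain carbon, two bonds along the chain from a sulfonyl sulfur in which 2-hydroxyethyl takes the place of acetoxy on a saturated chain carbon, two bonds along the chain from a sulfonyl sulfur. For the measured compounds named here, no measured pair shows this change. In this assay the expected step is a 1.6-fold higher number from compound 2 to compound 3 (0.20 log units; within the scatter) and so a modest rise that may stay within the scatter. For compound 3 the estimated value is 1400 ug/mL with a range of 500 ug/mL to 3500 ug/mL expected.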

Compound 3, solubility: 9900 ug/mL
Estimate against measurement, compound 3: 7.1-fold (0.85 log units) below, outside the stated range (above it).
By their numbers in this assay, from the lowest: compounds 1 and 2 (each within the scatter of the next); then compound 3.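

At this position, on a saturated chain carbon, two bonds along the chain from a sulfonyl sulfur, replacing acetoxy with 2-hydroxyethyl gives an 11-fold higher number from compound 2 to compound 3 (1.05 log units; beyond the scatter) in this assay. The same difference, read one bond further out, is 2-acetoxyethyl to 4-hydroxybutyl, so a hydrogen-bond donor enters and the chain end changes in a single step. Nothing available accounts for the size of this step.

This one pair cannot separate the loss of acetoxy from the gain of the hydroxyl-ended chain. It also leaves open how a longer chain, or an amine or carboxylic acid at the chain end, would read out.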